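This account rests on a few compounds, and the source may have more. Where it says the series, first, only, none or still open, it means among the compounds named here.

Of the compounds shown here, two have been measured so far. Compound 1 `COC1Cc2c(csc2-c2cccnc2)C2(CCN(Cc3ccccc3)CC2)O1` and compound 2 `COC1Cc2sc(-c3ccccc3)cc2C2(CCN(Cc3ccccc3)CC2)O1` share the same spiro core and the same benzyl group on the nitrogen, and differ in how the aromatic substituent is arranged on the thiophene-fused ring. In an assay on membranes from brain for displacement of a labelled ligand from Sigma non-opioid intracellular receptor 1 (Cavia porcellus), read by scintillation counting, with a stated time of 120 min (on this read-out higher numbers stand for weaker inhibition and lower numbers for stronger inhibition), compound 1 gives 2.2 nM. In this assay compound 2 gives 5.5 nM, which is the higher of the two numbers; the gap between compound 1 and compound 2 lies beyond the usual scatter of this measurement, so compound 2 is the weaker binder of the pair.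

Compound 3 `COC1Cc2sc(-c3ccc(-c4ccccc4)cc3)cc2C2(CCN(Cc3ccccc3)CC2)O1` is not yet measured. It differs from compound 2 in one place: phenyl in place of hydrogen on an aromatic carbon, so that compound 3 carries a biphenyl in place of the simple phenyl of compound 2. Within the data shown here, no measured pair in this set shows what such a change does. Among the measured compounds shown here, with no step to lean on, the expectation for compound 3 is that the step from compound 2 a 1.4-fold lower number from compound 2 to compound 3 (0.14 log units; within the scatter) stays within the scatter, with a lean toward slightly stronger binding. The estimate for compound 3 is therefore 4 nM, with a range from 1 nM to 15 nM.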

Compound 3, inhibition constant: 220 nM
Compound 3: middle estimate off by 55-fold (1.74 log units), on the low side; the measured number lies above the stated range.
By their numbers in this assay, from the lowest: compound 1; then compound 2; then compound 3.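

In this assay, phenyl in place of hydrogen on an aromatic carbon, para to a large group, gives a 40-fold higher number from compound 2 to compound 3 (1.60 log units; beyond the scatter) and counts as a large step, so this place on the six-membered aromatic ring of compound 2 does not take an added phenyl without a heavy loss of binding. Among these compounds, this is the first change in a single place, and it shows that a change on the aromatic substituent alone, with the shared core and the benzyl group on the nitrogen left as they are, can move the number far more than the gap between compound 1 and compound 2 does. Nothing at hand accounts for the size of this step.

From the compounds shown here alone, it stays open whether the loss belongs to phenyl in particular or would also follow a smaller group at the same place, such as fluorine, methyl or methoxy, and whether an amine or a carboxylic acid there would behave alike. Also open, going by these compounds, is whether the same change would cost as much on the differently arranged aromatic substituent of compound 1.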